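The source may hold more compounds than are shown below. What is called first, only, known or untested is meant among the compounds shown, and "the series" means these compounds.

Measured compounds:
compound 1 `CCOC(=O)c1cnc(NC2CC2)n2nc(-c3ccco3)nc12`: 2260 nM
compound 2 `CCOC(=O)c1cnc(NCc2ccc(F)cc2)n2nc(-c3ccco3)nc12`: 1970 nM

In a functional assay on CHO cells for antagonist activity at adenosine receptor A2b (Homo sapiens) (a lower number here means a stronger inhibitor, a higher number a weaker inhibitor), compound 2 gives 1970 nM and compound 1 gives 2260 nM; the two numbers sit within the scatter of each other, so neither compound stands apart. Among the measured compounds shown here, the single measured step, a 1.1-fold lower number from compound 1 to compound 2 (0.06 log units; within the scatter), swaps one group on the ring nitrogen for another and leaves the ester untouched.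

Compound 3 `O=C(O)c1cnc(NCc2ccc(F)cc2)n2nc(-c3ccco3)nc12` differs from compound 2 by hydrogen in place of ethyl on an oxygen next to a carbonyl group. For the measured compounds named here, no measured step touches this part of the molecule, so nothing in the data shows how large the effect will be or in which direction. The estimate therefore rests on the structural change alone and carries a wide range. Compound 3 is expected to give a weaker result, a step of a 4.1-fold higher number from compound 2 to compound 3 (0.61 log units; beyond the scatter), with an estimated value of 8000 nM and a plausible range from 1500 nM to 40000 nM.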

Compound 3, inhibition constant: > 30000 nM
Compound 3 ended at the assay's limit (the forecaster's own chance of this, stated with the estimate: 30%); middle value at least 3.7-fold (0.57 log units) away from the limit.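

Until now only the group on the nitrogen had changed, and that swap left the two numbers within the scatter of each other. The ester is the first place shown where a single change moves the result beyond the scatter: in this assay, hydrogen in place of ethyl, which turns ethoxycarbonyl into carboxy, gives an at least 15-fold higher number from compound 2 to compound 3 (1.18 log units; beyond the scatter). Compound 3 stands at a limit of the assay, not at a number: the limit of > 30000 nM in this assay, at which 1 of the 3 values shown sits.

From the compounds shown here alone, what stays open is whether the ethyl group itself matters or whether other groups would serve at this place, such as a methyl ester, an ester with a longer chain or an amide. Going by these compounds, it is also open whether the same change would have a similar effect with cyclopropyl in place of 4-fluorobenzyl on the nitrogen.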